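Adding a trifluoromethyl group to compound 3

The compounds below may be only part of what the source reports. "The series", "measured", "known", "first", "only" and "open" are said of these compounds alone.

In an ADME assay on HepG2 cells (Homo sapiens) for cytotoxicity (on this read-out lower numbers stand for higher toxicity in this test and higher numbers for lower toxicity in this test), compound 3 (`CSc1cccc(N2C(=O)CN(c3ccccc3)CC2C(=O)NC2CCCC2)c1`) gives > 50000 nM as a limit of the assay, not a number. Compound 2 (`CSc1cccc(N2C(=O)CN(c3ccccc3)CC2(C)C(=O)NC2CCCC2)c1`) gives > 50000 nM as a limit too. The set thus shows the limit of > 50000 nM in this assay, at which 2 of the 3 values shown sit, as its main feature. Among the compounds with values here, the one measured step, a step that the two limits leave unreadable from compound 2 to compound 3 (hydrogen in place of methyl on a saturated ring carbon), has no readable size, so it offers no measure for what comes next. Compound 4 (`CSc1cccc(N2C(=O)CN(c3cccc(C(F)(F)F)c3)CC2C(=O)NC2CCCC2)c1`) carries a new change (trifluoromethyl in place of hydrogen on an aromatic carbon): trifluoromethyl in place of hydrogen on an aromatic carbon, meta to a large group. Within the data shown here, the only numerical guide is compound 1 (`CSc1cccc(NC(=O)c2cc3ccc(C(F)(F)F)cc3n2CC(C)C(=O)NC2CCCC2)c1`), which also holds a trifluoromethyl group, on a different core, and gives 7100 nM as a true number. A modest move toward higher toxicity in this test is therefore expected, estimated as an at least 1.6-fold lower number from compound 3 to compound 4 (0.22 log units; that floor lies within the scatter) on these numbers, though the result may again be only a limit. Compound 4 is expected near 30000 nM with a range from 10000 nM to 70000 nM as the estimate.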

Compound 4, half-maximal cytotoxic concentration: 20000 nM
Beside the measured number, compound 4's estimate is 1.5-fold (0.18 log units) above it; the measured number falls inside the stated range.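

Going from phenyl to 3-(trifluoromethyl)phenyl gives an at least 2.5-fold lower number from compound 3 to compound 4 (0.39 log units; beyond the scatter) and so yields the first true number on this core in this assay, showing that this aromatic position can change the read-out. Compound 3 gives > 50000 nM as a limit of the assay, not a number. As far as these compounds go, the full size of the step therefore stays unknown and may be larger, because the starting compound sits at that limit: the limit of > 50000 nM in this assay, at which 2 of the 4 values shown sit.

The compounds shown leave open whether the shift belongs to trifluoromethyl itself, or whether a chlorine, an amine or a carboxylic acid in the same place would also lower the number. They also leave open how trifluoromethyl would act elsewhere on this ring, or on compound 2, which carries the extra methyl.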